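The source may report more compounds than this note shows. Statements on the series, on what has been measured and on what is new or still open speak of the compounds shown alone.

Measured compounds and their values:

- compound 1, `COc1ncnc2c1c(-c1ccsc1)cn2[C@@H]1O[C@H](CO)[C@@H](O)[C@H]1O`: in a functional assay on K562 cells (Homo sapiens), read by MTT assay, with a stated time of 72 h (a higher number here means a weaker inhibitor, a lower number a stronger inhibitor), compound 1 gives 90 nM
- compound 2, `COc1ncnc2c1c(-c1cccs1)cn2[C@@H]1O[C@H](CO)[C@@H](O)[C@H]1O`: in this assay compound 2 gives 70 nM
- compound 3, `CNc1ncnc2c1c(-c1cccs1)cn2[C@@H]1O[C@H](CO)[C@@H](O)[C@H]1O`: for compound 3 this assay reports only a limit, > 20000 nM

Compound 2 and compound 1 differ by thiophen-3-yl in place of thiophen-2-yl on an aromatic carbon. The step between them is a 1.3-fold higher number from compound 2 to compound 1 (0.11 log units; within the scatter), so the two values cannot be told apart. Compound 3 differs from compound 2 by methylamino in place of methoxy on an aromatic carbon, and that step is an at least 280-fold higher number from compound 2 to compound 3 (2.45 log units; beyond the scatter). Compound 3 sits at the limit of > 20000 nM in this assay, at which 1 of the 3 values shown sits, which is a limit and not a number.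

Compound 4, `CNc1ncnc2c1c(-c1ccsc1)cn2[C@@H]1O[C@H](CO)[C@@H](O)[C@H]1O`, is not yet measured in this assay. Among the measured compounds shown here, it differs from compound 3 by thiophen-3-yl in place of thiophen-2-yl on an aromatic carbon, the same change at the same place as the one from compound 2 to compound 1; the two cores differ by the change described between compound 2 and compound 3. Because a 1.3-fold higher number from compound 2 to compound 1 (0.11 log units; within the scatter) was within the scatter, the same change on the core of compound 3 is expected to leave compound 3's result essentially where it stands, above the limit of this assay. Set beside that earlier step, the expected step is a step that the limit leaves unreadable from compound 3 to compound 4. Compound 4 is therefore estimated to give 30000 nM, most likely again reported only as a limit.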

Compound 4, half-maximal inhibitory concentration: > 20000 nM
Compound 4 was reported as a limit; the forecaster's own chance of this, stated with the estimate: 85%; the middle value does not contradict the limit.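

In this assay compound 4 gives > 20000 nM, which is a limit and not a number, so the steps between thiophen-2-yl and thiophen-3-yl on the core of compound 3 cannot be read. Methylamino in place of methoxy gives an at least 220-fold higher number from compound 1 to compound 4 (2.34 log units; beyond the scatter), which shows that the large weakening seen with thiophen-2-yl also appears with thiophen-3-yl, so in this pair of cores the direction of the change carries over and the result stays beyond the scatter on both. What this does not show is whether the change has the same size on the two cores, or how far either methylamino compound lies past the limit: the same change on two cores in this assay, an at least 280-fold higher number (2.45 log units; beyond the scatter) from compound 2 to compound 3 and an at least 220-fold higher number (2.34 log units; beyond the scatter) from compound 1 to compound 4; the limit leaves it open whether they differ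

The compounds shown leave open whether the weakening belongs to methylamino alone or would also follow from another group in place of methoxy, such as an unsubstituted amine, dimethylamino or ethoxy. They also leave open whether other rings in place of the thiophenes, such as phenyl or furan-2-yl, would keep values like those of compound 1 and compound 2 on the methoxy core.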